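Compound 3 to compound 4: a phenoxy replacement

A few compounds are considered here, and "the series" means these few. Any claim that something is new, unique, unknown or untested is made for them only; others in the source may bear on it.

Measured in a functional assay on the whole organism for inhibition, with Rattus norvegicus as the target; a higher number here means that more compound is needed for the effect, a lower number that less compound is needed:
Compound 1 `COc1ccc(Cc2ccc(OC(C)(Cc3ccc(Cl)cc3)C(=O)O)cc2)cc1`: < 10 mg/kg, a limit
Compound 2 `CC(Cc1ccc(Cl)cc1)(Oc1ccc(Cc2ccc(Cl)cc2)cc1)C(=O)O`: > 10 mg/kg, a limit
Compound 3 `CC(Cc1ccc(Cl)cc1)(Oc1ccc(C2CCSc3ccccc32)cc1)C(=O)O`: 10 mg/kg

For the measured compounds named here, compound 3 gives 10 mg/kg, the only value of the three that is a number rather than a limit. Compound 4 `CC(Cc1ccc(Cl)cc1)(Oc1ccc(Oc2ccccc2)cc1)C(=O)O` differs from it at one place: a group of 7 heavy atoms (6 carbon, 1 oxygen; one six-membered aromatic ring of carbon only) in place of a group of 10 heavy atoms (9 carbon, 1 sulfur; one six-membered non-aromatic ring with 1 hetero atom, one six-membered aromatic ring of carbon only), on an aromatic carbon. Two measured steps change that same place, a number no lower from compound 1 to compound 3 (the limit leaves the size open) and a number no higher from compound 2 to compound 3 (the limit leaves the size open). The size of neither can be read, and they give no direction for the new group. In this assay, the expected change is therefore none beyond the scatter, no change at the digits printed from compound 3 to compound 4 (within the scatter). Compound 4 is expected at 10 mg/kg, with an estimated range of 4 mg/kg to 25 mg/kg.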

Compound 4, dose for half-maximal effect: < 1 mg/kg
Compound 4: no number, only a limit; the forecaster's own chance of this, stated with the estimate: 40%; at least 10-fold (1.00 log units) between middle value and limit.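

In this assay, for the compounds shown here, phenoxy at this place gives an at least 10-fold lower number from compound 3 to compound 4 (1.00 log units; beyond the scatter) and an at least 10-fold lower number from compound 2 to compound 4 (1.00 log units; beyond the scatter), the first steps here whose size can be read, both beyond the scatter. The reading for compound 4 is a limit, not a number: the limit of < 1 mg/kg in this assay, at which 1 of the 4 values shown sits. The steps that involve compound 1 and two limits cannot be read, so phenoxy cannot be ranked against 4-methoxybenzyl. On these data alone, whether an amine link in place of the phenoxy oxygen, or a chloro on the phenoxy ring, would keep this gain remains open.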